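The compounds below may be only part of what the source reports. "The series", "measured", "known", "first", "only" and "open" are said of these compounds alone.

Measured in an in vivo ADME assay on the whole organism for metabolic stability, with Rattus norvegicus as the target, using cassette dosing; on this read-out lower numbers stand for a shorter-lived compound and higher numbers for a longer-lived compound:
compound 1 `O=C(Nc1ccc(-n2ccccc2=O)cn1)[C@H]1C[C@](O)(c2ccccc2)CN1C(=O)Nc1ccc(Cl)cc1` gives 2.9 h
compound 2 `Cc1ccc([C@@]2(O)C[C@H](C(=O)Nc3ccc(-n4ccccc4=O)cn3)N(C(=O)Nc3ccc(Cl)cc3)C2)cc1` gives 1.8 h
compound 3 `Cc1ccccc1[C@@]1(O)C[C@H](C(=O)Nc2ccc(-n3ccccc3=O)cn2)N(C(=O)Nc2ccc(Cl)cc2)C1` gives 1.3 h

Compound 3 has the lowest number of the three in this assay, but its gap to compound 2, a 1.4-fold lower number from compound 2 to compound 3 (0.14 log units; within the scatter), is within the scatter, so the two are not separated; only the gap to compound 1, a 2.2-fold lower number from compound 1 to compound 3 (0.35 log units; beyond the scatter), is beyond the scatter, and modest at that. The remaining measured step, a 1.6-fold lower number from compound 1 to compound 2 (0.21 log units; within the scatter), is within the scatter.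

Compound 4 `O=C(Nc1ccc(-n2ccccc2=O)cn1)[C@H]1C[C@](O)(c2ccccc2Cl)CN1C(=O)Nc1ccc(Cl)cc1` differs from compound 3 by chloro in place of methyl on an aromatic carbon. Within the data shown here, no measured step exchanges a chloro for a methyl, so the direction of this change has no direct anchor. Among the measured compounds shown here, what bears on it is that the steps touching this phenyl ring, a 2.2-fold lower number from compound 1 to compound 3 (0.35 log units; beyond the scatter) and a 1.4-fold lower number from compound 2 to compound 3 (0.14 log units; within the scatter), were small throughout the series, with only one of three steps beyond the scatter. A step of similar size is therefore expected, a 1.1-fold higher number from compound 3 to compound 4 (0.03 log units; within the scatter), with no clear direction. Compound 4 is estimated at 1.4 h in this assay, with a range from 0.7 h to 2.8 h.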

Compound 4, half-life: 2.9 h
The estimate for compound 4 lay 2.1-fold (0.32 log units) below the measured number, outside the stated range (above it).
By their numbers in this assay, from the lowest: compounds 3, 2, 1 and 4 (each within the scatter of the next, the first and the last beyond it).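

In this assay, among these compounds, this is the first exchange of one group for another on the aromatic carbon ortho to a large group, and methyl and chloro are separated there: the reading runs a 2.2-fold higher number from compound 3 to compound 4 (0.35 log units; beyond the scatter) and is modest. Chloro on this carbon leaves the number level with the parent phenyl, with no change at the digits printed from compound 1 to compound 4 (within the scatter) as the step, so a group at this place does not by itself go with the lower number of compound 3; which group it is matters. The reading is a 1.6-fold higher number from compound 2 to compound 4 (0.21 log units; within the scatter) and does not separate that pair, and no measurement here gives a reason for the gap between methyl and chloro.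

As far as these compounds go, whether fluoro, methoxy or trifluoromethyl on the same carbon would read like chloro or like methyl stays open. So does whether the exchange of methyl for chloro gives a similar step on the 4-methylphenyl of compound 2.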